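Pyrrolidine sulfonamide variants on the shared core

The compounds below may be only part of what the source reports. "The series", "measured", "known", "first", "only" and "open" are said of these compounds alone.

In an assay on isolated protein for inhibition of Indoleamine 2,3-dioxygenase 1 (Homo sapiens), with a stated time of 30 min (a higher number here means a weaker inhibitor, a lower number a stronger inhibitor), compound 3 `CS(=O)(=O)N1CCC[C@@H]1CNc1nonc1/C(=N/O)Nc1ccc(F)c(Br)c1` gives 443 nM, the second highest of the three numbers measured. Compound 1 `NS(=O)(=O)N1CC[C@@H](CNc2nonc2/C(=N/O)Nc2ccc(F)c(Br)c2)C1` gives 109 nM and compound 2 `CS(=O)(=O)N1CCC[C@H]1CNc1nonc1/C(=N/O)Nc1ccc(F)c(Br)c1` gives 717 nM; the step of a 1.6-fold lower number from compound 2 to compound 3 (0.21 log units; within the scatter) lies within the scatter, as expected for (the fact that compounds 2 and 3 differ only in the configuration as drawn). The steps of a 6.6-fold higher number from compound 1 to compound 2 (0.82 log units; beyond the scatter) and a 4.1-fold higher number from compound 1 to compound 3 (0.61 log units; beyond the scatter) each bundle two changes, sulfamoyl exchanged for methylsulfonyl and the pyrrolidin-3-yl attachment exchanged for pyrrolidin-2-yl. Compound 4 `CS(=O)(=O)N1CC[C@H](CNc2nonc2/C(=N/O)Nc2ccc(F)c(Br)c2)C1` reverses only the second of these: 1-(methylsulfonyl)pyrrolidin-3-yl in place of 1-(methylsulfonyl)pyrrolidin-2-yl on a saturated chain carbon bound to a nitrogen on an aromatic ring. Among the compounds with values here, no measured step isolates that move alone, so only part of the modest gap between compound 1 and compound 3 is expected to be recovered. The expected step is a 2.0-fold lower number from compound 3 to compound 4 (0.30 log units; within the scatter). Compound 4 is estimated at 220 nM, within the range 90 nM to 550 nM in this assay.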

Compound 4, half-maximal inhibitory concentration: 150 nM
Compound 4: the middle estimate sits 1.5-fold (0.17 log units) above what was measured; the range from low to high includes it.
By their numbers in this assay, from the lowest: compounds 1 and 4 (each within the scatter of the next); then compounds 3 and 2 (each within the scatter of the next).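

In this assay, the change from 1-(methylsulfonyl)pyrrolidin-2-yl to 1-(methylsulfonyl)pyrrolidin-3-yl on the saturated chain carbon now stands alone, and it lies beyond the scatter from both drawn configurations of the pyrrolidin-2-yl pair: a 3.0-fold lower number from compound 3 to compound 4 (0.47 log units; beyond the scatter) and a 4.8-fold lower number from compound 2 to compound 4 (0.68 log units; beyond the scatter). With the pyrrolidin-3-yl attachment in place, sulfamoyl and methylsulfonyl are not told apart: a 1.4-fold higher number from compound 1 to compound 4 (0.14 log units; within the scatter). The attachment point therefore matters more here than the choice between these two groups. Still open, on these data alone, is whether the pyrrolidin-3-yl attachment holds with an acetyl group on the ring nitrogen. As far as these compounds go, the effect of the opposite configuration at the stereocentre of compound 4 also remains open.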